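The source may hold more compounds than are shown below. What is called first, only, known or untested is meant among the compounds shown, and "the series" means these compounds.

Compound 2, `CC1(C)N=C(N)N=C(N)N1c1ccc(OCCCCNC(=O)Nc2cccc(S(=O)(=O)F)c2)c(Cl)c1`, is the most potent of the three measured compounds: in an assay on isolated protein for inhibition of Dihydrofolate reductase (Mus musculus) (a higher number here means a more potent compound, by a factor of ten per unit of this negative logarithm, a lower number a less potent compound), compound 2 gives 7.7. Compound 1, `CC1(C)N=C(N)N=C(N)N1c1ccc(OCCCNC(=O)c2ccc(S(=O)(=O)F)cc2)c(Cl)c1`, gives 7.34 in this assay, and compound 3, `CC1(C)N=C(N)N=C(N)N1c1ccc(OCCCNC(=O)Nc2cccc(S(=O)(=O)F)c2)c(Cl)c1`, gives 7.28. Compound 1 and compound 3 differ by one change, (4-(fluorosulfonyl)phenyl in place of (3-(fluorosulfonyl)phenyl)amino on a carbonyl carbon), and the step is a number 0.06 log units higher from compound 3 to compound 1 (within the scatter). How the cores of compound 2 and compound 3 differ is not broken down here.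

Compound 4, `CC1(C)N=C(N)N=C(N)N1c1ccc(OCCCCNC(=O)c2ccc(S(=O)(=O)F)cc2)c(Cl)c1`, is not yet measured. It arises from compound 2 by 4-(fluorosulfonyl)phenyl in place of (3-(fluorosulfonyl)phenyl)amino on a carbonyl carbon, the same kind of change that turned compound 3 into compound 1. Because that earlier step a number 0.06 log units higher from compound 3 to compound 1 (within the scatter) stayed within the scatter, the step from compound 2 to compound 4 is expected to be a number 0.05 log units higher from compound 2 to compound 4 (within the scatter). Compound 4 is therefore estimated at 7.75 in this assay, with a likely range from 7.35 to 8.15.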

Compound 4, logarithm of the reciprocal of the active concentration, log(1/C): 7.66
Compound 4: middle estimate off by 0.09 log units, on the high side; low and high end bracket the measured number.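

In this assay the same exchange on the core of compound 2 gives a number 0.04 log units lower from compound 2 to compound 4 (within the scatter). The two steps agree across the two cores: the same change on two cores in this assay, a number 0.06 log units higher (within the scatter) from compound 3 to compound 1 and a number 0.04 log units lower (within the scatter) from compound 2 to compound 4, 0.10 log units apart, within the scatter of two such steps. This shows that the change carried over between these two cores in this assay, but two cores cannot show that it would hold on any other, and neither step favours one group over the other.

The compounds shown leave open how (4-(fluorosulfonyl)phenyl)amino or 3-(fluorosulfonyl)phenyl on the same carbonyl carbon would compare, so the two parts of the change remain unseparated. They also leave open whether the exchange would stay this small on a longer chain.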